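Swapping cyano for nitro on the ring bound to triazole

The source may hold more compounds than are shown below. What is called first, only, known or untested is meant among the compounds shown, and "the series" means these compounds.

Compound 1 `COc1ccc(/C=C\C(=O)O)c(OCc2cn(-c3cccc(C#N)c3)nn2)c1CC=C(C)C` gives 22900 nM in a functional assay on A-431 cells (Homo sapiens) for cytotoxicity, read by MTT assay, with a stated time of 24 h (a higher number here means a weaker inhibitor, a lower number a stronger inhibitor), the higher of the two numbers measured, while compound 2 `COc1ccc(/C=C\C(=O)O)c(OCc2cn(-c3ccc(CO)cc3)nn2)c1CC=C(C)C` gives 16400 nM, with a 1.4-fold lower number from compound 1 to compound 2 (0.14 log units; within the scatter). Compound 3 `COc1ccc(/C=C\C(=O)O)c(OCc2cn(-c3cccc([N+](=O)[O-])c3)nn2)c1CC=C(C)C` differs from compound 1 by nitro in place of cyano on an aromatic carbon. For the measured compounds named here, the one measured step, from compound 1 to compound 2, touched the same ring and stayed within the scatter, so for compound 3 no step beyond the scatter is expected in this assay, with a 1.1-fold lower number from compound 1 to compound 3 (0.06 log units; within the scatter). Compound 3 is therefore estimated at 20000 nM, within 8000 nM to 50000 nM.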

Compound 3, half-maximal inhibitory concentration: 18400 nM
The estimate for compound 3 lay 1.1-fold (0.04 log units) above the measured number; the measured number falls inside the stated range.
By their numbers in this assay, from the lowest: compounds 2, 3 and 1 (each within the scatter of the next).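

In this assay, nitro in place of cyano on this aromatic carbon, meta to a large group, leaves the number within the scatter (a 1.2-fold lower number from compound 1 to compound 3 (0.10 log units; within the scatter)). The 3-nitrophenyl and 4-(hydroxymethyl)phenyl groups also cannot be told apart here (a 1.1-fold higher number from compound 2 to compound 3 (0.05 log units; within the scatter)). No measurement is available to explain why these groups read alike.

For the compounds shown here, since every step so far stays within the scatter, it remains open whether any group at this position can shift the number beyond it. An amine or a carboxylic acid on this ring carbon would test that.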